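Lengthening the Chain from Compound 3 to Compound 4

The compounds below may be only part of what the source reports. "The series", "measured", "known", "first", "only" and "open" are said of these compounds alone.

Compound 3 `Cn1c(=O)[nH]c2ccc(OCCc3ccccc3)cc21` is the starting point here. In an assay on cells for inhibition of Amine oxidase [flavin-containing] B (Homo sapiens), read by fluorescence, with stated times of 30 min and 15 min, tested at 1 uM (on this read-out higher numbers stand for more inhibition at the one concentration tested (going by the name of the read-out) and lower numbers for less inhibition), compound 3 is recorded as "not active" (no number reported), with no number behind it. Two neighbours give context: compound 1 `Cn1c(=O)[nH]c2cc(OCc3ccccc3)ccc21` is likewise "not active" (no number reported) in this assay, while compound 2 `Cn1c(=O)[nH]c2ccc(OCCc3cccc(Cl)c3)cc21`, which carries a chlorine on its outer ring, reaches 13.7% in this assay. Compound 4 `Cn1c(=O)[nH]c2ccc(OCCCc3ccccc3)cc21` differs from compound 3 in one place: benzyl in place of phenyl on a saturated chain carbon, two bonds along the chain from an oxygen on an aromatic ring. For the measured compounds named here, no measured pair shows what this change does in this assay, so no step beyond the usual scatter is expected, in either direction. Compound 4 is therefore estimated at 8% in this assay, within a range from 0% to 25%.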

Compound 4, a percentage reported as inhibition, at one concentration (the size of the read-out at that concentration, not a potency): 14%
Estimate against measurement, compound 4: 6 percentage points below; the range from low to high includes it.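

Benzyl in place of phenyl at this chain carbon turns a compound without a number into one with a number: in this assay compound 3 is recorded as "not active" (no number reported), while compound 4 gives 14%. Replacing 3-chlorophenyl with benzyl gives a number 0.3 percentage points higher from compound 2 to compound 4 (within the scatter), so in this pair a number appears with or without the chlorine on the outer ring. No measurement shown here explains this result.

As far as these compounds go, whether a longer chain than that of compound 4, or an amine on its outer ring, would move the inhibition beyond the scatter stays open.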